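Fluoro to Bromo on an Aromatic Carbon

The source may hold more compounds than are shown below. What is called first, only, known or untested is meant among the compounds shown, and "the series" means these compounds.

Of the compounds shown here, three built on one shared core have been measured, and all three sit at the weak end of a functional assay, with a stated time of 6 min; on this read-out lower numbers stand for stronger inhibition and higher numbers for weaker inhibition. The smallest of them, compound 1 `S=c1[nH]nc(-c2ccc3c(c2)OCCO3)o1`, gives 10600 nM. Compound 2 `Fc1cccc(NCn2nc(-c3ccc4c(c3)OCCO4)oc2=S)c1`, which carries a (3-fluorophenyl)amino group, gives 6620 nM, the lowest of the three numbers shown. Compound 3 `FC(F)(F)c1cc(NCn2nc(-c3ccc4c(c3)OCCO4)oc2=S)cc(C(F)(F)F)c1`, which bears two trifluoromethyl groups, gives 9320 nM. The gaps from compound 2 to compound 3 and to compound 1 both lie within the scatter, so no order among the three can be read from these numbers.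

Compound 4 `S=c1oc(-c2ccc3c(c2)OCCO3)nn1CNc1cccc(Br)c1` has not yet been measured. It differs from compound 2 in one place: bromo in place of fluoro on an aromatic carbon. Among the compounds with values here, no measured pair of compounds shows a step of this kind, and the three measured numbers lie close together, so the expected step is small, none beyond the scatter in either direction. In this assay compound 4 is expected to give 5500 nM, within a range of 2500 nM to 12000 nM. That estimate means an expected step of a 1.2-fold lower number from compound 2 to compound 4 (0.08 log units; within the scatter).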

Compound 4, half-maximal inhibitory concentration: 10800 nM
Beside the measured number, compound 4's estimate is 2.0-fold (0.29 log units) below it, within the range that was stated.
By their numbers in this assay, from the lowest: compounds 2, 3, 1 and 4 (each within the scatter of the next).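

In this assay, within the data shown here, bromo in place of fluoro is the first change in a single place that can be read, and it comes to a 1.6-fold higher number from compound 2 to compound 4 (0.21 log units; within the scatter). At this position on the aromatic ring, then, the read-out cannot tell the two halogens apart, so compound 2 and compound 4 have to be treated as alike in this assay. Nothing measured here bears on why the two compounds read alike.

As far as these compounds go, it remains open whether a group of a different kind on this same aromatic carbon, such as an amine, a carboxylic acid or a methoxy group, would give a step beyond the scatter. From the compounds shown here alone, it is also open whether bromo in place of fluoro would read the same way on a different core.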